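The compounds below may be only part of what the source reports. "The series", "measured", "known", "first", "only" and "open" are said of these compounds alone.

Measured so far, in an ADME assay on HeLa cells (Homo sapiens) for cytotoxicity, read by ATP content, with a stated time of 3 days; a lower number here means that less compound is tolerated, a higher number that more compound is tolerated:

Compound 1 `CS(=O)(=O)CCCn1c(Cn2c(=O)n(C3CN(S(C)(=O)=O)C3)c3ccncc32)cc2cc(Cl)ccc21` gives > 50000 nM, which is a limit of the assay and not a number.
Compound 2 `CS(=O)(=O)c1ccc(-n2c(=O)n(Cc3cc4cc(Cl)ccc4n3CCCC#N)c3cnccc32)cc1` gives > 50000 nM, again a limit of the assay rather than a number.
Compound 3 `O=C(O)CCCn1c(Cn2c(=O)n(C3CC3)c3ccncc32)cc2cc(Cl)ccc21` gives > 50000 nM, also a limit of the assay and not a number.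

Where compound 1 stands can therefore only be stated loosely: its value is a limit, and the two further values shown are limits as well. Among the measured compounds shown here, no step between two measured compounds is available, since no two of them differ in one place only. For the measured compounds named here, the single piece of evidence is the limit of > 50000 nM in this assay, at which 3 of the 3 values shown sit, which says that all three measured compounds sit at the same boundary of this assay.

Compound 4 `CC(C)n1c(=O)n(Cc2cc3cc(Cl)ccc3n2CCCS(C)(=O)=O)c2cnccc21` is the compound not yet measured. It differs from compound 1 by isopropyl in place of 1-(methylsulfonyl)azetidin-3-yl on an aromatic nitrogen. With every measured compound at the limit, the step from compound 1 to compound 4 is expected to be none beyond the scatter, namely a step that the limit leaves unreadable from compound 1 to compound 4, because the limit of > 50000 nM in this assay, at which 3 of the 3 values shown sit, places all three shown values at that same limit. Compound 4 is accordingly estimated to give 60000 nM in this assay, within a range from 20000 nM to 200000 nM, and most likely to be reported as a limit as well.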

Compound 4, half-maximal cytotoxic concentration: > 50000 nM
Compound 4 was reported as a limit (the forecaster's own chance of this, stated with the estimate: 85%); the middle value is on the limit's open side.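

No step can be read from compound 1 to compound 4 in this assay, where both are reported as limits and not as numbers: the limit of > 50000 nM in this assay, at which 4 of the 4 values shown sit. The compounds shown leave open what concentration of any of them the cells would actually tolerate, and whether any structural change among them alters that concentration at all.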